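Adding a Furan Ring to Compound 3

The source may report more compounds than this note shows. Statements on the series, on what has been measured and on what is new or still open speak of the compounds shown alone.

Three compounds were measured in a functional assay on MCF7 cells (Homo sapiens) for cytotoxicity, read by MTT assay, with a stated time of 48 h; a higher number here means a weaker inhibitor, a lower number a stronger inhibitor:
- compound 1 `COc1ccc(-n2nnnc2C(Nc2ccc([Se][Se]c3ccc(NC(c4nnnn4-c4ccc(OC)cc4)C(C)C)cc3)cc2)C(C)C)cc1` gives >= 100000 nM, a limit of the assay rather than a number;
- compound 2 `COC(CC(OC)OC)Cn1nnnc1C(Nc1ccc([Se][Se]c2ccc(NC(c3nnnn3CC(CC(OC)OC)OC)C(C)C)cc2)cc1)C(C)C` gives >= 100000 nM, likewise a limit;
- compound 3 `CC1=C([Se]c2ccc(NCc3nnnn3C(C)(C)C)cc2)C(=O)c2ccccc2C1=O` gives 42000 nM.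

Going by the values given here, compound 3 therefore holds the only actual number in this set. Among the compounds with values here, the other two results sit at the limit of >= 100000 nM in this assay, at which 2 of the 3 values shown sit, so no step between measured compounds can be followed, and nothing here says how any single change moves the read-out.

The next compound, compound 4 `CC1=C([Se]c2ccc(NC(c3ccco3)c3nnnn3C(C)(C)C)cc2)C(=O)c2ccccc2C1=O`, is built from compound 3 by one change: furan-2-yl in place of hydrogen on a saturated chain carbon bound to an aromatic carbon and a nitrogen on an aromatic ring. Whether this furan ring helps or hurts cannot be read from the compounds shown, because none of them carries a comparable change against a measured partner. The safest expectation is a step no larger than the usual scatter, in no fixed direction, with compound 4 staying in the same weak range as compound 3.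

On that basis the expected step from compound 3 to compound 4 is a 1.2-fold lower number from compound 3 to compound 4 (0.08 log units; within the scatter). The estimate for compound 4 in this assay is 35000 nM, expected to fall between 12000 nM and 100000 nM.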

Compound 4, half-maximal inhibitory concentration: >= 100000 nM
Compound 4: a limit, no number (the forecaster's own chance of this, stated with the estimate: 20%); middle value at least 2.8-fold (0.45 log units) away from the limit.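

In this assay, furan-2-yl in place of hydrogen on a saturated chain carbon bound to an aromatic carbon and a nitrogen on an aromatic ring gives an at least 2.3-fold higher number from compound 3 to compound 4 (0.37 log units; beyond the scatter), so this place on the molecule does respond to a change, and here the added ring makes the compound a weaker inhibitor by more than the scatter. Compound 4 gives >= 100000 nM, which is a limit of the assay and not a number, so the step shows a direction and a smallest size but no true size. Compound 3 thus remains the only compound in this set with an actual number: the limit of >= 100000 nM in this assay, at which 3 of the 4 values shown sit.

What remains open is whether the weaker result belongs to the furan ring itself or would follow from any group placed on this carbon, and nothing shown gives a reason for the change. A thiophene ring or a carboxylic acid at the same place, set against compound 3, would begin to separate these two readings, provided the result came back as a number rather than a limit.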